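Methoxy step carried from the small core to the large

The source may report more compounds than this note shows. Statements on the series, on what has been measured and on what is new or still open speak of the compounds shown alone.

Measured compounds:
Compound 1 `C#CCN(c1nc(-c2ccccc2)no1)C1CCCCC1`: 109 ug/mL
Compound 2 `CC(=O)OC[C@H]1O[C@H](OC[C@@H](Cn2cc(CN(c3nc(-c4ccccc4)no3)C3CCCCC3)nn2)OC(C)=O)C=C[C@@H]1OC(C)=O`: 19.9 ug/mL
Compound 3 `C#CCN(c1nc(-c2ccc(OC)cc2)no1)C1CCCCC1`: 72.5 ug/mL

All three were run in an ADME assay on HepG2 cells (Homo sapiens) for cytotoxicity, read by MTT assay, with a stated time of 48 h; on this read-out higher numbers stand for lower toxicity in this test and lower numbers for higher toxicity in this test. Compound 1 and compound 3 share a core and differ only by methoxy in place of hydrogen on an aromatic carbon; this change gave a 1.5-fold lower number from compound 1 to compound 3 (0.18 log units; within the scatter). Compound 2 carries a much larger core; the difference between its core and the core of compound 1 is not broken down here. In this assay compound 2 gives the lowest number of the three, and its gap to each of the other two lies beyond the scatter.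

Compound 4 `COc1ccc(-c2noc(N(Cc3cn(C[C@H](CO[C@@H]4C=C[C@H](OC(C)=O)[C@@H](COC(C)=O)O4)OC(C)=O)nn3)C3CCCCC3)n2)cc1` is not yet measured. It differs from compound 2 by methoxy in place of hydrogen on an aromatic carbon, which is the same change as the one from compound 1 to compound 3; the change thus occurs twice among the compounds shown, once measured and once pending. Among the compounds with values here, with only one measured instance, and that one within the scatter, the step from compound 2 to compound 4 is expected to be small, about a 1.3-fold lower number from compound 2 to compound 4 (0.12 log units; within the scatter), resting on compound 1 and compound 3 with a 1.5-fold lower number from compound 1 to compound 3 (0.18 log units; within the scatter). For compound 4 the estimate in this assay is 15 ug/mL, with a range from 8 ug/mL to 30 ug/mL.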

Compound 4, half-maximal cytotoxic concentration: 141 ug/mL
For compound 4 the middle estimate is 9.4-fold (0.97 log units) below the measured one; measured number outside the range, above it.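

In this assay, methoxy in place of hydrogen on an aromatic carbon gives a 7.1-fold higher number from compound 2 to compound 4 (0.85 log units; beyond the scatter), and the two cores do not share one step for this change: the same change on two cores in this assay, a 1.5-fold lower number (0.18 log units; within the scatter) from compound 1 to compound 3 and a 7.1-fold higher number (0.85 log units; beyond the scatter) from compound 2 to compound 4, 11-fold (1.03 log units) apart, beyond the scatter of two such steps

The step measured for this change on the core of compound 1 cannot be carried over, in size or in direction, to the core of compound 2. This rests on one pair per core, so it shows that the step depends on the core in these two cases, but it gives neither a rule for other cores nor a reason for the difference.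

The compounds shown leave open whether other groups in the same place, such as a chlorine atom or an amine, would also give different steps on the two cores. They also leave open which part of the larger core of compound 2 goes with the different step, as no compound shown carries only part of that core.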